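The source may hold more compounds than are shown below. What is called first, only, known or untested is meant among the compounds shown, and "the series" means these compounds.

In an assay on HL-60 cells for inhibition of glutathione S-transferase P (Homo sapiens), read by spectrophotometry, tested at 5 uM (a lower number here means less inhibition, a higher number more inhibition at the concentration tested (going by the name of the read-out)), compound 1 `C=C(C)C(=O)c1ccc(OCc2nc(-c3ccccc3)cs2)cc1Cl` gives 100%, compound 3 `C=C(C)C(=O)c1ccc(OCc2nc(-c3ccc([N+](=O)[O-])cc3)cs2)cc1Cl` gives 86.7%, and compound 2 `C=C(CC)C(=O)c1ccc(OCc2nc(-c3ccc(C(F)(F)F)cc3)cs2)cc1Cl` gives 19.7%. Going by the values given here, compound 3 thus stands second highest of the three; the single change from compound 1 to compound 3, nitro in place of hydrogen on an aromatic carbon, brought a number 13.3 percentage points lower from compound 1 to compound 3 (beyond the scatter). Compound 4 `C=C(C)C(=O)c1ccc(OCc2nc(-c3ccc(C(F)(F)F)cc3)cs2)cc1Cl` differs from compound 3 in one place: trifluoromethyl in place of nitro on an aromatic carbon. Among the compounds with values here, no measured step isolates this swap. Compound 2 carries the same trifluoromethyl but also another change on the shared core, so its reading of 19.7% against compound 1 blends two effects. The step is nevertheless expected to be a fall beyond the scatter, a number 46.7 percentage points lower from compound 3 to compound 4 (beyond the scatter), with wide uncertainty. Compound 4 is expected to give 40%, between 10% and 80%.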

Compound 4, a percentage reported as inhibition, at one concentration (the size of the read-out at that concentration, not a potency): 72.3%
Beside the measured number, compound 4's estimate is 32.3 percentage points below it, and the stated range covers the measured number.
By their numbers in this assay, from the lowest: compound 2; then compound 4; then compound 3; then compound 1.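

In this assay, trifluoromethyl on the aromatic carbon para to a large group keeps most of the reading: there is a number 27.7 percentage points lower from compound 1 to compound 4 (beyond the scatter), and swapping it for nitro gives a number 14.4 percentage points lower from compound 3 to compound 4 (beyond the scatter). The low reading of compound 2 therefore comes mainly from the chain change, since hydrogen in place of methyl on the saturated chain carbon gives a number 52.6 percentage points higher from compound 2 to compound 4 (beyond the scatter). No measurement here explains why these steps occur. Open questions are how an amine or a carboxylic acid would read at the aromatic carbon, and how a longer chain would read at the saturated chain carbon.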